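Cyclic sulfonate ester: cytotoxicity outlook for a benzoyl analogue

The source may hold more compounds than are shown below. What is called first, only, known or untested is meant among the compounds shown, and "the series" means these compounds.

Compound 1 `CCC1(Cc2ccccc2)OS(=O)(=O)C=C1OCc1ccccc1Cl`: >= 20000 nM
Compound 2 `CCC1(Cc2ccccc2)OS(=O)(=O)C=C1OCc1cccc(Cl)c1`: >= 20000 nM
Compound 3 `CCC1(Cc2ccccc2)OS(=O)(=O)C=C1OCCc1ccccc1`: >= 20000 nM

In an ADME assay on HEL cells (Homo sapiens) for cytotoxicity, with a stated time of 3 days (on this read-out lower numbers stand for higher toxicity in this test and higher numbers for lower toxicity in this test), compound 1 gives >= 20000 nM, which is a limit of the assay and not a number. Compound 2 likewise gives only a limit, >= 20000 nM. Compound 3 also reaches only a limit, >= 20000 nM. All three values sit at the limit of >= 20000 nM in this assay, at which 3 of the 3 values shown sit, so compound 3 stands at the same place as the other two measured compounds, and the steps a step that the two limits leave unreadable from compound 1 to compound 2, a step that the two limits leave unreadable from compound 1 to compound 3 and a step that the two limits leave unreadable from compound 2 to compound 3 have no readable size.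

Compound 4 `CCC1(Cc2ccccc2)OS(=O)(=O)C=C1OC(=O)c1ccccc1` differs from compound 3 by benzoyl in place of phenethyl on an oxygen on an unsaturated carbon. Every measured step is unreadable because of the two limits, so none of them shows a direction for this change, and no step beyond the scatter can be expected. Compound 4 is therefore expected to sit again at the limit, estimated at 20000 nM with a range from 10000 nM to 40000 nM. The expected step of a number no higher from compound 3 to compound 4 (the limit leaves the size open) is none beyond the scatter.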

Compound 4, minimum cytotoxic concentration: > 400000 nM
Compound 4 was reported as a limit (the forecaster's own chance of this, stated with the estimate: 80%); middle value at least 20-fold (1.30 log units) from the limit.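

In this assay, within the data shown here, compound 4 gives > 400000 nM, which is a limit of the assay and not a number, so no step from compound 1, compound 2 or compound 3 to compound 4 can be read. The compounds shown leave open what size of change, if any, benzoyl brings in place of phenethyl, 2-chlorobenzyl or 3-chlorobenzyl.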